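Permeability notes on the series: compound 1 toward compound 3

A few compounds are considered here, and "the series" means these few. Any claim that something is new, unique, unknown or untested is made for them only; others in the source may bear on it.

Measured so far:
compound 1 `Cc1oc(-c2ccccc2Cl)nc1CN1CCC(C(=O)NCCCN2C[C@H](C)C[C@H](C)C2)CC1` — 352 10^-6 cm/s
compound 2 `Cc1ccccc1-c1nc(CN2CCC(C(=O)NCCCN3CCC(C)CC3)CC2)c(C)o1` — 425 10^-6 cm/s

In a physicochemical assay for permeability, using PAMPA (on this read-out higher numbers stand for higher permeability and lower numbers for lower permeability), compound 1 gives 352 10^-6 cm/s, the lower of the two numbers in hand. Compound 2 gives 425 10^-6 cm/s, which lies within the scatter of compound 1, so no order can be read between the two. Among the compounds with values here, no pair of measured compounds differs in a single place, so no step of that kind has been seen in this assay yet.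

Compound 3 `Cc1ccc(-c2nc(CN3CCC(C(=O)NCCCN4C[C@H](C)C[C@H](C)C4)CC3)c(C)o2)c(C)c1` is not yet measured. It differs from compound 1 by 2,4-dimethylphenyl in place of 2-chlorophenyl on an aromatic carbon. Within the data shown here, nothing measured so far bears directly on this exchange. Both numbers in hand sit high and close together, and the step from compound 1 to compound 3 is expected to stay within the scatter, with a 1.1-fold higher number from compound 1 to compound 3 (0.03 log units; within the scatter) as the estimated step. Compound 3 is expected to give 380 10^-6 cm/s, with a range of 200 10^-6 cm/s to 700 10^-6 cm/s. That expectation rests on compound 1 at 352 10^-6 cm/s and on compound 2 at 425 10^-6 cm/s, which together set the level seen so far.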

Compound 3, apparent permeability: 353 10^-6 cm/s
For compound 3 the middle estimate is 1.1-fold (0.03 log units) above the measured one; measured number inside the range.
By their numbers in this assay, from the lowest: compounds 1, 3 and 2 (each within the scatter of the next).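

In this assay, within the data shown here, 2,4-dimethylphenyl in place of 2-chlorophenyl on an aromatic carbon gives a 1.0-fold higher number from compound 1 to compound 3 (0.00 log units; within the scatter) and is the first single-place step available. On this read-out, the two groups cannot be told apart at this position, next to the ring nitrogen and the ring oxygen, although one has 7 heavy atoms including a chlorine and the other has 8 heavy atoms, all carbon, and neither has a hydrogen-bond donor or acceptor. No measurement in hand offers an account of this result.

On these data alone, all of this rests on a single exchange between two uncharged groups with a six-membered aromatic ring of carbon only, so it remains open whether a pyridine ring in their place, or an amine or a carboxylic acid on the phenyl ring, would stay at the same level in this assay. Among these compounds, compound 2 differs from compound 1 and from compound 3 in more than one place, so no single-place step yet speaks to any other part of the molecule.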